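Replacing an amide by a urea in a cytotoxicity series

The source may hold more compounds than are shown below. What is called first, only, known or untested is meant among the compounds shown, and "the series" means these compounds.

Of the compounds shown here, three built on a shared core have been tested for how much of each a melanoma cell line tolerates. Compound 1 `O=C(Nc1cccc(-n2cc(-c3ccncc3)c(-c3ccc(Cl)c(O)c3)n2)c1)Nc1ccc(Cl)c(Cl)c1` and compound 3 `O=C(Nc1cccc(-n2cc(-c3ccncc3)c(-c3ccc(Cl)c(O)c3)n2)c1)Nc1cc(C(F)(F)F)cc(C(F)(F)F)c1` attach a second aromatic ring to the core through a urea, while compound 2 `COc1cc(-c2nn(-c3cccc(NC(=O)c4cccc(C(F)(F)F)c4)c3)cc2-c2ccncc2)ccc1Cl` does so through an amide. In a functional assay on UACC-257 cells (Homo sapiens) for inhibition, read by sulforhodamine B assay, with a stated time of 48 h (a higher number here means that more compound is tolerated, a lower number that less compound is tolerated), compound 3 gives 10600 nM. For compound 1 the assay reports only a limit, > 32500 nM, and that is the limit of > 32500 nM in this assay, at which 1 of the 3 values shown sits. For compound 2 the result is also only a limit, > 50000 nM, namely (the limit of > 50000 nM in this assay, at which 1 of the 3 values shown sits). Compound 2 therefore stands without a number of its own, at the top of what the three results show.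

Compound 4 `COc1cc(-c2nn(-c3cccc(NC(=O)Nc4ccc(Cl)c(C(F)(F)F)c4)c3)cc2-c2ccncc2)ccc1Cl` is drawn from compound 2 by a single change: (4-chloro-3-(trifluoromethyl)phenyl)amino in place of 3-(trifluoromethyl)phenyl on a carbonyl carbon. With it compound 4 becomes a urea, as compound 1 and compound 3 are. Those two show that a urea on this core may give either a limit or a measurable value, so no firm direction can be read from them. A downward step, toward less tolerated, is expected to be small, and the step of an at least 1.6-fold lower number from compound 2 to compound 4 (0.22 log units; that floor lies within the scatter) is estimated to stay close to the scatter. Compound 4 is expected to give about 30000 nM in this assay, with a likely range from 9000 nM to 100000 nM.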

Compound 4, concentration lethal to 50% of the cells: 29200 nM
Compound 4: middle estimate off by 1.0-fold (0.01 log units), on the high side, and the stated range covers the measured number.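

Going by these compounds alone, replacing 3-(trifluoromethyl)phenyl with (4-chloro-3-(trifluoromethyl)phenyl)amino on a carbonyl carbon turns the amide into a urea and gives an at least 1.7-fold lower number from compound 2 to compound 4 (0.23 log units; that floor lies within the scatter) in this assay and so provides the first step that can be read at this position. From the compounds shown here alone, the true size of this step stays unknown, and only its floor is printed, because compound 2 has a limit instead of a number: the limit of > 50000 nM in this assay, at which 1 of the 4 values shown sits. As that floor lies within the scatter, the result does not establish a real drop, and since the change brings in the amino nitrogen and the chlorine together, the step cannot be credited to either one alone.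

The compounds shown leave open whether the urea link or the chlorine matters more, a question that a urea carrying a plain 3-(trifluoromethyl)phenyl group on the core of compound 2 could help settle. They also leave open how the cells would tolerate compounds with a quite different group at this position, such as an amine or a carboxylic acid on the outer ring.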